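Adding a Second Chloro: Two Cores, One Change

A few compounds are considered here, and "the series" means these few. Any claim that something is new, unique, unknown or untested is made for them only; others in the source may bear on it.

Of the compounds shown here, three built on the same pattern have been tested in a functional assay on PC-12 cells (Rattus norvegicus) for cytotoxicity, read by MTT assay, with stated times of 3 h and 2 h, tested at 10 uM; on this read-out lower numbers stand for a weaker effect and higher numbers for a stronger effect at the one concentration tested. Compound 1 `O=C(CCCCC1CCSS1)NCc1cn(CCCOc2ccc3cc(-c4ccc(Cl)cc4)c(=O)oc3c2)nn1` gives 67.8%. Compound 2 `O=C(CCCCC1CCSS1)NCc1cn(CCCOc2ccc3cc(-c4ccc(Cl)c(Cl)c4)c(=O)oc3c2)nn1` differs from compound 1 by chloro in place of hydrogen on an aromatic carbon, and compound 2 gives 49.6%. The step of a number 18.2 percentage points lower from compound 1 to compound 2 (beyond the scatter) is the only measured effect of this change.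

Compound 3 `O=C(CCCCC1CCSS1)NCc1cn(CCCCOc2ccc3cc(-c4ccc(Cl)cc4)c(=O)oc3c2)nn1` has a different core; the difference between the two cores is not broken down here. In this assay compound 3 gives 61.8%, which lies close to the number for compound 1 and is clearly above that of compound 2.

Compound 4 `O=C(CCCCC1CCSS1)NCc1cn(CCCCOc2ccc3cc(-c4ccc(Cl)c(Cl)c4)c(=O)oc3c2)nn1` has not yet been measured. It stands to compound 3 as compound 2 stands to compound 1: the change is chloro in place of hydrogen on an aromatic carbon, at the same place in both pairs, so it is the same change on a different core. If it acts as it did between compound 1 and compound 2, the step from compound 3 to compound 4 is expected to be about a number 17.8 percentage points lower from compound 3 to compound 4 (beyond the scatter), because of a number 18.2 percentage points lower from compound 1 to compound 2 (beyond the scatter). On that basis compound 4 is estimated to give 44% in this assay, between 30% and 58%.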

Compound 4, a percentage reported as activity, at one concentration (the size of the read-out at that concentration, not a potency): 58.9%
Estimate against measurement, compound 4: 14.9 percentage points below; measured number outside the range, above it.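

In this assay, the second chloro does not repeat its earlier result on the core of compound 3: the step is a number 2.9 percentage points lower from compound 3 to compound 4 (within the scatter), so going from 4-chlorophenyl to 3,4-dichlorophenyl makes no clear difference on this core. The two steps also differ from each other: the same change on two cores in this assay, a number 18.2 percentage points lower (beyond the scatter) from compound 1 to compound 2 and a number 2.9 percentage points lower (within the scatter) from compound 3 to compound 4, 15.3 percentage points apart, beyond the scatter of two such steps. In this series, then, the result of this change depends on the core that carries it, and a step measured on one core is a poor guide to the step on the other, although these two pairs give only the size of each step and do not show what in the cores sets them apart.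

Going by these compounds, it remains open whether a different group at the same place on the ring, such as fluoro, methoxy or an amine, would behave alike on both cores or differ as chloro does. With only two cores shown, it is also unknown how the same change would fare on a core with a longer chain.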